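The compounds below may be only part of what the source reports. "The series", "measured", "known", "first", "only" and "open" are said of these compounds alone.

Measured so far in the series:
compound 1 `COCc1cc(CN2CCCC2)c(O)c2ncccc12`: 11000 nM
compound 2 `COCc1cc(CN2CCCCC2)c(O)c2ncccc12`: 9330 nM
compound 3 `Oc1c(C(c2cccnc2)N2CCCC2)ccc2cccnc12`: 40700 nM

In a functional assay on MES-SA cells (Homo sapiens) for inhibition, with a stated time of 72 h (a higher number here means a weaker inhibitor, a lower number a stronger inhibitor), compound 1 gives 11000 nM and compound 2 gives 9330 nM. The change between them is piperidin-1-yl in place of pyrrolidin-1-yl on a saturated chain carbon bound to an aromatic carbon, and it made a 1.2-fold lower number from compound 1 to compound 2 (0.07 log units; within the scatter). Compound 3 gives 40700 nM in this assay, the highest number of the three. The difference between the core of compound 1 and the core of compound 3 is not broken down here; the two values show compound 3 with the higher number by a margin beyond the scatter.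

Compound 4 `Oc1c(C(c2cccnc2)N2CCCCC2)ccc2cccnc12` has not been measured in this assay. It differs from compound 3 by piperidin-1-yl in place of pyrrolidin-1-yl on a saturated chain carbon bound to two aromatic carbons. This is the same kind of change as from compound 1 to compound 2, not the same: there the place is on a saturated chain carbon bound to an aromatic carbon, here on a saturated chain carbon bound to two aromatic carbons. The expected step is a 1.2-fold lower number from compound 3 to compound 4 (0.07 log units; within the scatter), set beside a 1.2-fold lower number from compound 1 to compound 2 (0.07 log units; within the scatter), and rests on that earlier step lying within the scatter. For compound 4 the estimate is 35000 nM, with a range of 15000 nM to 80000 nM expected.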

Compound 4, half-maximal inhibitory concentration: 13500 nM
Beside the measured number, compound 4's estimate is 2.6-fold (0.41 log units) above it, and the stated range ends above it.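

In this assay, piperidin-1-yl in place of pyrrolidin-1-yl on a saturated chain carbon bound to two aromatic carbons gives a 3.0-fold lower number from compound 3 to compound 4 (0.48 log units; beyond the scatter), a step beyond the scatter, whereas the same exchange on the core of compound 1 gave a step within it. Set side by side, the two steps cannot be told apart, so the data are compatible with the change carrying over from one core to the other: the same change on two cores in this assay, a 1.2-fold lower number (0.07 log units; within the scatter) from compound 1 to compound 2 and a 3.0-fold lower number (0.48 log units; beyond the scatter) from compound 3 to compound 4, 2.6-fold (0.41 log units) apart, within the scatter of two such steps

This does not show that the step has a fixed size or that piperidin-1-yl gives a lower number on every core in the series, since the comparison rests on a single pair per core, and the place of the change also differs between them.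

Still open, from the compounds shown here alone, is whether the step would hold on a further core. Also open, going by these compounds, is how other amines in this place would compare, for example morpholin-4-yl or an open-chain dimethylamino group.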